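Trimming methoxymethoxy to methoxy: expected cytotoxicity of compound 4

This account rests on a few compounds, and the source may have more. Where it says the series, first, only, none or still open, it means among the compounds named here.

In a toxicity assay on MDCK cells (Canis lupus familiaris) for cytotoxicity, read by crystal violet staining, with a stated time of 48 h (a lower number here means that less compound is tolerated, a higher number that more compound is tolerated), compound 2 `COCOc1ccc(CN(Cc2ccc(C(C)(C)C)cc2)Cc2cc3cc(C)ccc3[nH]c2=O)cc1` gives 6400 nM. Among the compounds with values here, that is the only plain number among the three measured compounds; the other two values are limits of the assay rather than numbers. Compound 1 `Cc1ccc2cc(CN(Cc3ccc(Cl)cc3)Cc3ccc(C(C)C)cc3)c(=O)[nH]c2c1` reaches only the limit > 33000 nM in this assay. Compound 3 `CCc1ccc2[nH]c(=O)c(CN(Cc3ccc(OCOC)cc3)Cc3ccc(C(C)(C)C)cc3)cc2c1` likewise reaches only the limit > 10000 nM in this assay. Within the data shown here, the one measured step, an at least 1.5-fold higher number from compound 2 to compound 3 (0.19 log units; that floor lies within the scatter), sits at a different place from the change considered here, and its size lies within the scatter. Compound 4 `COc1ccc(CN(Cc2ccc(C(C)(C)C)cc2)Cc2cc3cc(C)ccc3[nH]c2=O)cc1` differs from compound 2 by hydrogen in place of methoxy on a saturated chain carbon bound to an oxygen on an aromatic ring, so the 4-(methoxymethoxy)phenyl becomes a 4-methoxyphenyl. Among the measured compounds shown here, no measured step touches this part of the molecule, so there is no direct guide to its effect. With only a small change in this assay seen so far, the step of a 1.1-fold higher number from compound 2 to compound 4 (0.04 log units; within the scatter) is expected to stay within the scatter, in no particular direction. Compound 4 is therefore estimated at 7000 nM, in the range 2500 nM to 20000 nM.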

Compound 4, half-maximal cytotoxic concentration: > 10000 nM
Compound 4: a limit, no number; the forecaster's own chance of this, stated with the estimate: 30%; middle value at least 1.4-fold (0.15 log units) away from the limit.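

In this assay, within the data shown here, the first measured step for this change, from 4-(methoxymethoxy)phenyl to 4-methoxyphenyl, is an at least 1.5-fold higher number from compound 2 to compound 4 (0.19 log units; that floor lies within the scatter). Compound 4 gives > 10000 nM, which is a limit of the assay and not a number, so the step has a floor but no known size. The same limit recurs among the compounds shown, so it offers little to separate them: the limit of > 10000 nM in this assay, at which 2 of the 4 values shown sit.

The compounds shown therefore leave open whether removing the methoxy from the saturated chain carbon bound to an oxygen on an aromatic ring makes a real difference in cytotoxicity, since the floor alone cannot settle that. Also open, from the compounds shown here alone, is how a different group in this place, such as a hydroxy group, an amine or a longer chain like ethoxy, would read in this assay.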